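Amino to Methoxy Swap in Cell Growth Inhibition

The source may hold more compounds than are shown below. What is called first, only, known or untested is meant among the compounds shown, and "the series" means these compounds.

Compound 1 `Nc1ccccc1/C=C/c1cccc(O)c1` and compound 2 `Nc1cccc(/C=C/c2ccccc2O)c1` are built from the same atoms joined differently; the difference between the two cores is not broken down here. In a functional assay on HT-29 cells (Homo sapiens) for inhibition, read by MTT assay, with a stated time of 2 days (on this read-out lower numbers stand for stronger inhibition and higher numbers for weaker inhibition), compound 1 gives 30 ug/mL and compound 2 gives 30.4 ug/mL. Compound 3 `COc1cccc(/C=C/c2ccccc2O)c1` carries methoxy in place of amino on an aromatic carbon and gives 26 ug/mL in this assay, so the step of a 1.2-fold lower number from compound 2 to compound 3 (0.07 log units; within the scatter) is small. Compound 4 `COc1ccccc1/C=C/c1cccc(O)c1` carries methoxy in place of amino on an aromatic carbon on the core of compound 1; here the group sits ortho rather than meta to the larger group, so this is the same kind of change, not the same. Because the step of a 1.2-fold lower number from compound 2 to compound 3 (0.07 log units; within the scatter) stayed within the scatter, a similarly small step a 1.2-fold lower number from compound 1 to compound 4 (0.06 log units; within the scatter) is expected. Compound 4 is therefore estimated at 26 ug/mL, likely between 13 ug/mL and 52 ug/mL.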

Compound 4, half-maximal inhibitory concentration: 17 ug/mL
The estimate for compound 4 lay 1.5-fold (0.18 log units) above the measured number; low and high end bracket the measured number.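

Set in this assay, methoxy in place of amino on the core of compound 1 gives a 1.8-fold lower number from compound 1 to compound 4 (0.25 log units; within the scatter), so this swap leaves no clear mark here. The same swap on the other core gives a matching picture, and the two steps do not differ by more than repeated measurements would: the same change on two cores in this assay, a 1.2-fold lower number (0.07 log units; within the scatter) from compound 2 to compound 3 and a 1.8-fold lower number (0.25 log units; within the scatter) from compound 1 to compound 4, 1.5-fold (0.18 log units) apart, within the scatter of two such steps Across these two cores, then, the swap carries over as a step too small to read, but this does not prove that it has no effect, and it says nothing about any core beyond these two.

The compounds shown leave open what a larger change would do in place of amino, such as a carboxylic acid or a longer chain like butoxy. They also leave open whether any such group would give a step that stands clear of the scatter.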